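From methoxymethyl to 1-hydroxy-1-methylethyl in compound 3

The source may report more compounds than this note shows. Statements on the series, on what has been measured and on what is new or still open speak of the compounds shown alone.

Among the compounds with values here, in an ADME assay (liver) for metabolic stability, with Liver microsome (Rattus norvegicus) as the target, using microsomes and NADPH, with a stated time of 30 min, tested at 1 uM (on this read-out lower numbers stand for slow clearance and higher numbers for fast clearance), compound 2 `COCC#Cc1cc(C(O)(C(F)(F)F)C(F)(F)F)cnc1N1CCN(S(=O)(=O)c2ccc(N)nc2)CC1` gives 399 mL.min-1.g-1, the higher of the two numbers so far. Compound 1 `Nc1ccc(S(=O)(=O)N2CCN(c3ncc(C(O)(C(F)(F)F)C(F)(F)F)cc3Br)CC2)cn1` gives 32 mL.min-1.g-1. Within the data shown here, the one measured step, a 12-fold higher number from compound 1 to compound 2 (1.10 log units; beyond the scatter), is large and beyond the scatter, with 3-methoxyprop-1-yn-1-yl in place of bromo on an aromatic carbon. Compound 3 `CC(C)(O)C#Cc1cc(C(O)(C(F)(F)F)C(F)(F)F)cnc1N1CCN(S(=O)(=O)c2ccc(N)nc2)CC1` has 1-hydroxy-1-methylethyl in place of methoxymethyl on a triple-bonded carbon. Among the measured compounds shown here, no measured step covers this exchange, so that single step bears on it only indirectly and the direction remains uncertain. In this assay a moderate fall is expected, much smaller in size than the measured step, and the expected step is a 2.5-fold lower number from compound 2 to compound 3 (0.40 log units; beyond the scatter). For compound 3 the estimate is 160 mL.min-1.g-1, with an expected range from 50 mL.min-1.g-1 to 450 mL.min-1.g-1.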

Compound 3, intrinsic clearance in microsomes: 16 mL.min-1.g-1
Estimate against measurement, compound 3: 10-fold (1.00 log units) above; the measured number lies below the stated range.
By their numbers in this assay, from the lowest: compounds 3 and 1 (each within the scatter of the next); then compound 2.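

In this assay, the high number of compound 2 is not tied to the triple-bonded carbon alone: with that carbon kept, 1-hydroxy-1-methylethyl in place of methoxymethyl gives a 25-fold lower number from compound 2 to compound 3 (1.40 log units; beyond the scatter). Against the bromo group, 3-hydroxy-3-methylbut-1-yn-1-yl gives a 2.0-fold lower number from compound 1 to compound 3 (0.30 log units; within the scatter), so the large step seen earlier does not hold for every chain on this triple bond, and the outcome at this position depends on the group at the far end of the chain. Nothing available here accounts for the size of this exchange.

The hydroxyl and the extra carbon enter together in compound 3, and the compounds shown do not separate their contributions. Going by these compounds, how an amine in place of the hydroxyl, or a longer chain carrying the hydroxyl, would read in this assay remains open.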